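The compounds below may be only part of what the source reports. "The series", "measured", "known", "first", "only" and "open" are said of these compounds alone.

In a functional assay on HeLa cells (Homo sapiens) for antiproliferative activity, read by MTT assay, with a stated time of 48 h (a lower number here means a stronger inhibitor, a higher number a weaker inhibitor), compound 1 (`CNCC(=O)Nc1cc(OC)ccc1C(=O)c1ccc(OC)c2c1C=CC(C)(C)O2`) gives 2170 nM and compound 2 (`COc1ccc(C(=O)c2cc(OC)c(OC)c(OC)c2)c(NC(=O)CO)c1`) gives 70 nM while compound 3 (`CNCC(=O)Nc1cc(OC)ccc1C(=O)c1cc(OC)c(OC)c(OC)c1`) gives 690 nM as the second highest of the three numbers. Compound 3 lies beyond the scatter from both of the others. The next structure is compound 4 (`COc1ccc(C(=O)c2cc(OC)c(OC)c(OC)c2)c(NC(=O)CN(C)C)c1`), which differs from compound 3 at one place: methyl in place of hydrogen on an amine nitrogen with methyl in place of hydrogen on an amine nitrogen, so that methylamino becomes dimethylamino. Among the measured compounds shown here, only one measured step concerns this chain. It is a 9.9-fold higher number from compound 2 to compound 3 (0.99 log units; beyond the scatter) with methylamino in place of hydroxy, and it lies beyond the scatter. For the measured compounds named here, that step is a different exchange, however, and no measured pair shows the effect of methyl in place of hydrogen on this nitrogen. It gives no direction for the new change, so no step beyond the scatter is expected in this assay here. The estimated step is a 1.2-fold lower number from compound 3 to compound 4 (0.06 log units; within the scatter) and rests on the value of compound 3. For compound 4 the expected value is 600 nM with an estimated range from 200 nM to 1800 nM as the likely span.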

Compound 4, half-maximal inhibitory concentration: 470 nM
The estimate for compound 4 lay 1.3-fold (0.11 log units) above the measured number; measured number inside the range.
By their numbers in this assay, from the lowest: compound 2; then compounds 4 and 3 (each within the scatter of the next); then compound 1.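

In this assay, among the compounds shown here, the methyl in place of hydrogen on the amine nitrogen gives a 1.5-fold lower number from compound 3 to compound 4 (0.17 log units; within the scatter) and so leaves the methylamino and dimethylamino compounds indistinguishable, a comparison that the earlier compounds could not offer. With dimethylamino in place of hydroxy on the saturated chain carbon bound to a carbonyl carbon, the data show a 6.7-fold higher number from compound 2 to compound 4 (0.83 log units; beyond the scatter) and thus a gap beyond the scatter for both amines, not for methylamino alone. Nothing at hand gives a reason for either step. Still open, going by these compounds, is whether an unsubstituted amine at this place, or a longer chain between the carbonyl and the nitrogen, would read like compound 3 and compound 4 or like compound 2. Also open, on these data alone, is whether the same methyl exchange would read alike on the core of compound 1.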